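A Piperazine Amide in Place of the Acid

A few compounds are considered here, and "the series" means these few. Any claim that something is new, unique, unknown or untested is made for them only; others in the source may bear on it.

Of the compounds shown here, three sharing one core have been measured in an assay on a protein complex for inhibition of CDK8/Cyclin C (Homo sapiens), with a stated time of 1 h, tested at 10 uM; a lower number here means less inhibition, a higher number more inhibition at the concentration tested (going by the name of the read-out). Compound 1 `CC(C)[C@@H](NC(=O)/C=C/c1ccncc1-c1ccc2ccccc2c1)C(=O)O` gives 77% in this assay, and this is the lowest of the three numbers. Compound 2 `Cn1ccc2cc(-c3cnccc3/C=C/C(=O)N3CCOCC3)ccc21` gives 97% in this assay, a number that stands higher than that of compound 1 and beyond the scatter. Compound 3 `NNC(=O)CCc1ccncc1-c1ccc2ccccc2c1` gives 102% in this assay, the furthest from compound 1, higher still and likewise beyond the scatter.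

The step now followed leads from compound 1 to compound 4 `CN1CCN(C(=O)/C=C/c2ccncc2-c2ccc3ccccc3c2)CC1`, which has not yet been measured in this assay. The change is 4-methylpiperazin-1-yl in place of (1-carboxy-2-methylpropyl)amino on a carbonyl carbon.

For the measured compounds named here, no step between two measured compounds that differ in a single place is available, so the size of this step rests on what the three numbers show. Because compound 2, which carries no (1-carboxy-2-methylpropyl)amino group, gives 97% in this assay, an increase is expected for compound 4. The expected step of a number 15 percentage points higher from compound 1 to compound 4 (beyond the scatter) is estimated to lie beyond the scatter, upward. For compound 4 the estimated value in this assay is 92%, with a range from 78% to 102%.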

Compound 4, a percentage reported as inhibition, at one concentration (the size of the read-out at that concentration, not a potency): 101%
The estimate for compound 4 lay 9 percentage points below the measured number; the range from low to high includes it.
By their numbers in this assay, from the lowest: compound 1; then compounds 2, 4 and 3 (each within the scatter of the next).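

In this assay, the carbonyl carbon of the shared core gets its first direct test in a single step, a number 24 percentage points higher from compound 1 to compound 4 (beyond the scatter), so 4-methylpiperazin-1-yl is accepted at this place in exchange for (1-carboxy-2-methylpropyl)amino, and the number rises. The exchange alters several features at once: the group that leaves has 2 hydrogen-bond donors, 1 defined stereocentre and no ring, while the group that enters has 0 hydrogen-bond donors, no stereocentre and one six-membered non-aromatic ring with 2 hetero atoms, and this one step cannot tell which of these features goes with the rise. No measurement is available that bears on why the number moved.

On these data alone, whether the rise needs the ring or follows from the loss of the carboxylic acid stays open, and a dimethylamino group or a piperazin-1-yl group without the methyl on the same carbonyl carbon would speak to that. A read-out at one concentration also leaves open how compound 4 and compound 1 compare in potency.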